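Swapping trifluoromethyl for fluoro on the fused ring

The source may hold more compounds than are shown below. What is called first, only, known or untested is meant among the compounds shown, and "the series" means these compounds.

Measured compounds:
Compound 1, `CCC(Nc1nnc(-c2ccc(OC)cc2)o1)[C@H]1CC[C@@H](c2ccnc3c(F)cc(F)cc32)CC1`, 14 nM in an assay on blood for inhibition of Indoleamine 2,3-dioxygenase 1 (Homo sapiens), read by mass spectrometry, with a stated time of 18 h; on this read-out lower numbers stand for stronger inhibition and higher numbers for weaker inhibition
Compound 2, `CCC(Nc1nnc(-c2ccc(OC)cc2)o1)[C@H]1CC[C@@H](c2ccnc3ccc(C(F)(F)F)cc32)CC1`, 50 nM

Both compounds share one core and differ only in how the fused ring is decorated. Going by the values given here, of the two numbers so far, compound 2 has the higher one, which on this read-out means the weaker inhibition. Compound 1 sits clearly below it, and the gap between the two lies beyond the usual scatter of repeated measurements. The two structures differ in more than one place, so nothing more than this ordering can be drawn from them.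

Compound 3, `CCC(Nc1nnc(-c2ccc(OC)cc2)o1)[C@H]1CC[C@@H](c2ccnc3ccc(F)cc32)CC1`, has not yet been measured. Compared with compound 2 the change is fluoro in place of trifluoromethyl on an aromatic carbon. Among the compounds with values here, no pair of measured compounds shows exactly this change, so the size of its effect is open. Because compound 1, which carries fluoro groups on the same fused ring, gives 14 nM, a modest move toward a lower number is expected, with the step from compound 2 to compound 3 estimated at a 2.0-fold lower number from compound 2 to compound 3 (0.30 log units; within the scatter). Compound 3 is therefore expected to give about 25 nM, within a range of 8 nM to 80 nM.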

Compound 3, half-maximal inhibitory concentration: 16 nM
Compound 3: middle estimate off by 1.6-fold (0.19 log units), on the high side; low and high end bracket the measured number.
By their numbers in this assay, from the lowest: compounds 1 and 3 (each within the scatter of the next); then compound 2.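

In this assay, the two compounds now differ in one place only, so the effect of this swap can be read directly: fluoro in place of trifluoromethyl on an aromatic carbon gives a 3.1-fold lower number from compound 2 to compound 3 (0.49 log units; beyond the scatter), a step beyond the usual scatter that the earlier pair, differing in more than one place, could not isolate. Going by these compounds alone, compound 3 also connects the earlier pair, as hydrogen in place of fluoro at the other ring carbon gives a 1.1-fold higher number from compound 1 to compound 3 (0.06 log units; within the scatter), which lies within the scatter, so the one swap from trifluoromethyl to fluoro is enough to reach the range of compound 1, and the additional fluoro of compound 1 makes no difference that this measurement can resolve. No measurement shown here explains why these numbers fall as they do.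

Within the data shown here, only two groups have been compared on this carbon, so two points cannot show whether the read-out follows any general trend across substituents. As far as these compounds go, how plain hydrogen, a chloro group, a methoxy group or a nitrile on this same carbon would compare with fluoro and trifluoromethyl remains open.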